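Series notes: changing the group on the aromatic nitrogen

A few compounds are considered here, and "the series" means these few. Any claim that something is new, unique, unknown or untested is made for them only; others in the source may bear on it.

For the measured compounds named here, in a functional assay on MKN-45 cells (Homo sapiens) for inhibition, read by CCK-8 assay, with a stated time of 24 h (a lower number here means a stronger inhibitor, a higher number a weaker inhibitor), compound 1 `O=C1Nc2ccc(F)cc2/C1=C/c1ccc(-c2cn(-c3ccccc3F)nn2)cc1` gives 8510 nM and compound 2 `O=C1Nc2ccc(F)cc2/C1=C/c1ccc(-c2cn(-c3cccc(Cl)c3)nn2)cc1` gives 14100 nM within the scatter of each other, and these are the only two numbers so far. Compound 3 `O=C1Nc2ccc(F)cc2/C1=C/c1ccc(-c2cn(-c3ccc(Cl)c(C(F)(F)F)c3)nn2)cc1` carries 4-chloro-3-(trifluoromethyl)phenyl in place of 3-chlorophenyl on an aromatic nitrogen, with 4-chloro-3-(trifluoromethyl)phenyl in place of 3-chlorophenyl on an aromatic nitrogen as the counted change. Going by the values given here, the one measured step at that nitrogen is a 1.7-fold higher number from compound 1 to compound 2 (0.22 log units; within the scatter) and stays within the scatter. On this single step, no change beyond the scatter is expected in this assay and no direction is favoured. The expected step is a 1.3-fold lower number from compound 2 to compound 3 (0.11 log units; within the scatter) in size. Compound 3 is estimated at 11000 nM with an expected range from 4000 nM to 30000 nM in this read-out.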

Compound 3, half-maximal inhibitory concentration: > 20000 nM
Compound 3 ended at the assay's limit; the forecaster's own chance of this, stated with the estimate: 10%; middle value at least 1.8-fold (0.25 log units) away from the limit.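

Compound 3 stands at a limit of the assay, not at a number, in this assay: the limit of > 20000 nM in this assay, at which 1 of the 3 values shown sits. For the compounds shown here, the change to 4-chloro-3-(trifluoromethyl)phenyl can be read only as a floor, an at least 1.4-fold higher number from compound 2 to compound 3 (0.15 log units; that floor lies within the scatter), while an at least 2.3-fold higher number from compound 1 to compound 3 (0.37 log units; beyond the scatter) is the first step at this nitrogen beyond the scatter. Neither step gives a lower number.

On these data alone, how far compound 3 lies past its limit stays open. Also open, as far as these compounds go, is how a group without a phenyl ring, such as a morpholine or a plain alkyl chain, would read on this nitrogen.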